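The compounds below may be only part of what the source reports. "The series", "measured", "known", "first", "only" and "open" are said of these compounds alone.

In a functional assay on A549 cells (Homo sapiens), read by MTT assay, with a stated time of 72 h (a higher number here means a weaker inhibitor, a lower number a stronger inhibitor), the measured compounds read as follows:
- Compound 1 `C#Cc1cn([C@@H]2O[C@H](CO)[C@@H](O)[C@H]2O)c2ncnc(C)c12` gives 19200 nM as a number
- Compound 2 `Nc1nc(N)c2c(-c3ccco3)cn([C@@H]3O[C@H](CO)[C@@H](O)[C@H]3O)c2n1` gives > 20000 nM as a limit
- Compound 3 `Cc1nc(N)c2c(-c3ccco3)cn([C@@H]3O[C@H](CO)[C@@H](O)[C@H]3O)c2n1` gives > 20000 nM as a limit

Compound 3 stands at the limit of > 20000 nM in this assay, at which 2 of the 3 values shown sit, so it has no number. Compound 4 `Cc1nc(N)c2c(I)cn([C@@H]3O[C@H](CO)[C@@H](O)[C@H]3O)c2n1` differs from compound 3 by iodo in place of furan-2-yl on an aromatic carbon. Going by the values given here, the one measured step, a step that the two limits leave unreadable from compound 2 to compound 3, has no readable size and concerns methyl in place of amino, so it sets no size or direction here. Among the compounds with values here, the only number belongs to compound 1 at 19200 nM, so a large step is not expected in this assay. The estimated step, an at least 1.2-fold lower number from compound 3 to compound 4 (0.09 log units; that floor lies within the scatter), is small at most. For compound 4 the expected value is 16000 nM, with an estimated range of 4000 nM to 30000 nM overall.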

Compound 4, half-maximal inhibitory concentration: 12100 nM
For compound 4 the middle estimate is 1.3-fold (0.12 log units) above the measured one; the range from low to high includes it.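

Putting iodo in place of furan-2-yl on this aromatic carbon gives a readable number in this assay, which neither compound 2 nor compound 3 gave. The change amounts to an at least 1.6-fold lower number from compound 3 to compound 4 (0.21 log units; that floor lies within the scatter), so the size of the step remains uncertain. Compound 2 and compound 3 both sit at a limit, and the step between them cannot be read: the limit of > 20000 nM in this assay, at which 2 of the 4 values shown sit.

The compounds shown leave open how chloro, bromo or an amine on this carbon would read in this assay. They also leave open whether amino in place of methyl would change the value with iodo present.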